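Inserting a methylene between the methoxyphenyl group and the core

A few compounds are considered here, and "the series" means these few. Any claim that something is new, unique, unknown or untested is made for them only; others in the source may bear on it.

Measured so far in a functional assay on FM3A cells (Mus musculus) for inhibition, read by cell counting, with a stated time of 2 days; a lower number here means a stronger inhibitor, a higher number a weaker inhibitor:
compound 1 `C=C(Br)C(=O)Nc1cccc(-c2cn3nc(Cc4ccccc4)sc3n2)c1` gives 3000 nM
compound 2 `C=C(Br)C(=O)Nc1cccc(-c2cn3nc(-c4ccc(OC)cc4)sc3n2)c1` gives 890 nM

Of the two numbers, compound 2 has the lower one, and the step of a 3.4-fold lower number from compound 1 to compound 2 (0.53 log units; beyond the scatter) lies beyond the scatter. Compound 3 `C=C(Br)C(=O)Nc1cccc(-c2cn3nc(Cc4ccc(OC)cc4)sc3n2)c1` is not yet measured. It differs from compound 2 in one place: 4-methoxybenzyl in place of 4-methoxyphenyl on an aromatic carbon. Within the data shown here, the only measured step that bears on this change is the one from compound 1 to compound 2, where a benzyl group was exchanged for a 4-methoxyphenyl group and gave a 3.4-fold lower number from compound 1 to compound 2 (0.53 log units; beyond the scatter). The change to compound 3 keeps the methoxy group but puts a methylene back between the ring and the core, so in this respect it runs against that step. Compound 3 is therefore expected to give a higher number, a 2.8-fold higher number from compound 2 to compound 3 (0.45 log units; beyond the scatter), with the estimate 2500 nM and a range from 900 nM to 7000 nM.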

Compound 3, half-maximal inhibitory concentration: 850 nM
Compound 3: middle estimate off by 2.9-fold (0.47 log units), on the high side, outside the stated range (below it).
By their numbers in this assay, from the lowest: compounds 3 and 2 (each within the scatter of the next); then compound 1.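

In this assay, extending the group on this aromatic carbon by a methylene, from 4-methoxyphenyl to 4-methoxybenzyl, gives a 1.0-fold lower number from compound 2 to compound 3 (0.02 log units; within the scatter), so with the methoxy group present, the number does not respond to this change. Adding the methoxy group to the benzyl group gives a 3.5-fold lower number from compound 1 to compound 3 (0.55 log units; beyond the scatter), which separates the two differences combined in the earlier step from compound 1 to compound 2: across these three compounds, the lower number goes with the methoxy group and not with removing the methylene. No measurement here gives a reason for this pattern.

As far as these compounds go, it remains open whether another group in place of the methoxy, such as an amine or a carboxylic acid, would give a similar number. From the compounds shown here alone, how a longer chain in place of the methylene would read is also open.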